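Allyl for ethyl on the aromatic nitrogen: notes on compound 3

This account rests on a few compounds, and the source may have more. Where it says the series, first, only, none or still open, it means among the compounds named here.

Measured so far:
- compound 1, `C=CCn1ccc(N2C[C@H](COC)OC2=O)c1`, in an assay for inhibition of Amine oxidase [flavin-containing] B (Bos taurus), read by fluorescence, with a stated time of 30 min (a lower number here means a stronger inhibitor, a higher number a weaker inhibitor), compound 1 gives 200000 nM
- compound 2, `CCn1ccc(N2C[C@H](CNC)OC2=O)c1`, in this assay compound 2 gives 18000 nM

For the measured compounds named here, of the two numbers in hand, compound 2 stands lowest; the only other compound, compound 1, sits well beyond the scatter above it. Going by the values given here, compound 1 and compound 2 differ in two places at once, so the two values show only that the pair spans a wide gap, not which change carries it.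

Compound 3, `C=CCn1ccc(N2C[C@H](CNC)OC2=O)c1`, is not yet measured. It keeps the whole of compound 2 except for one change: vinyl in place of methyl on a saturated chain carbon bound to an aromatic nitrogen. Among the compounds with values here, nothing measured so far isolates this change; the single pair in hand does not separate the chain on the aromatic nitrogen from the side chain on the shared core.

Within the data shown here, with no measured step to anchor it, the expectation is a small step, a 1.1-fold higher number from compound 2 to compound 3 (0.05 log units; within the scatter), not beyond the scatter in either direction. Compound 3 is estimated at 20000 nM in this assay, with a range from 7000 nM to 60000 nM.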

Compound 3, inhibition constant: 2000 nM
Compound 3: middle estimate off by 10-fold (1.00 log units), on the high side; measured number outside the range, below it.
By their numbers in this assay, from the lowest: compound 3; then compound 2; then compound 1.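

In this assay, for the compounds shown here, vinyl in place of methyl on a saturated chain carbon bound to an aromatic nitrogen gives a 9.0-fold lower number from compound 2 to compound 3 (0.95 log units; beyond the scatter) and so shows, for the first time in a single-place pair, that this position responds to the change by more than the scatter. With the allyl group held fixed, methylamino in place of methoxy on a saturated chain carbon bound to a saturated ring carbon gives a 100-fold lower number from compound 1 to compound 3 (2.00 log units; beyond the scatter) and thus gives the side chain a step of its own, also beyond the scatter, which the earlier pair could not separate from the change on the other chain. Nothing in hand accounts for either step.

The compounds shown leave open whether the step from ethyl to allyl follows the double bond or the longer chain, a question that a propyl group would address, with a propargyl group or a still longer chain extending the same series. Also open, going by these compounds, are whether the allyl step holds with methoxy on the side chain, and how a primary amine or a dimethylamino group would compare with methylamino.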